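The source may report more compounds than this note shows. Statements on the series, on what has been measured and on what is new or still open speak of the compounds shown alone.

Series notes. Among the compounds with values here, compound 1 `CN(c1ccccc1)S(=O)(=O)c1ccc(NC(=O)c2ccc(Cl)cc2Cl)cc1` is the only member with a number: in a functional assay on HEK293 cells for agonist activity at probable G-protein coupled receptor 27 (Homo sapiens), read by a luciferase reporter and beta-arrestin recruitment, with a stated time of 10 min (on this read-out lower numbers stand for smaller maximal responses and higher numbers for larger maximal responses), compound 1 gives 50%. Compound 2 `COc1ccc(NS(=O)(=O)c2ccc(NC(=O)c3ccc(Cl)cc3Cl)cc2)cc1` has no result, and in this assay compound 2 stands at "not determined" (no result reported). Compound 3 `O=C(Nc1ccc(S(=O)(=O)Nc2ccc(Cl)cc2)cc1)c1ccc(Cl)cc1Cl` likewise carries no single number; in this assay compound 3 stands at "not determined" (no result reported), and one further member of the set is in the same position. The step to compound 4 `O=C(Nc1ccc(S(=O)(=O)Nc2cccc(Cl)c2)cc1)c1ccc(Cl)cc1Cl` is 3-chlorophenyl in place of 4-chlorophenyl on a sulfonamide nitrogen. Within the data shown here, no measured pair shows what this change does, so the expected step is of unknown direction and is taken as none beyond the scatter. Compound 4 is expected to give 50%, estimated between 20% and 80%. That expectation rests on compound 1 alone, which gives 50%.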

Compound 4, largest response reached (Emax), in percent of the reference or control that the assay uses: 40%
The estimate for compound 4 lay 10 percentage points above the measured number, and the stated range covers the measured number.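

In this assay replacing methyl(phenyl)amino with (3-chlorophenyl)amino on a sulfonyl sulfur gives a number 10 percentage points lower from compound 1 to compound 4 (within the scatter), so a response of this size persists with this different group at that place. Nothing at hand explains this result.

The steps involving compound 2 and compound 3, including the change from 4-chlorophenyl to 3-chlorophenyl, cannot be read. Going by these compounds, whether an amine or a carboxylic acid in place of the chlorine keeps the response at this level remains open.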